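This account rests on a few compounds, and the source may have more. Where it says the series, first, only, none or still open, it means among the compounds named here.

Measured so far in a functional assay on the whole organism (strain albino) for inhibition, with Rattus norvegicus as the target, read by paw edema, with stated times of 30 min and 3 h, at a dose of 100 mg/kg by the oral route; a higher number here means more inhibition at the dose given (going by the name of the read-out), a lower number less inhibition: compound 1 `Nc1ccc(C(=O)/C=C/c2ccco2)cc1` gives 42%; compound 2 `O=C(CBr)Nc1ccc(C(=O)/C=C/c2ccc(Cl)cc2)cc1` gives 59%; compound 3 `COc1ccc(/C=C/C(=O)c2ccc(NC(=O)CBr)cc2)cc1` gives 46%.

Compound 2 stands highest of the three, with compound 3 nearest and compound 1 furthest, both beyond the scatter. Compound 4 `O=C(CBr)Nc1ccc(C(=O)/C=C/c2ccco2)cc1` differs from compound 2 by furan-2-yl in place of 4-chlorophenyl on a double-bonded chain carbon bound to a double-bonded chain carbon. Among the measured compounds shown here, the one measured step that touches the same part of the molecule, a number 13 percentage points lower from compound 2 to compound 3 (beyond the scatter), shows that altering this aryl group can cost a modest amount. Compound 1, which already carries the furan-2-yl group but lacks the bromoacetamide, sits well under compound 2. A drop of similar size is therefore expected, a number 11 percentage points lower from compound 2 to compound 4 (beyond the scatter), in this assay. Compound 4 is estimated at 48%, within a range from 37% to 59%.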

Compound 4, a percentage reported as inhibition, in the whole organism at one dose (the size of the read-out at that dose, not a potency): 41%
For compound 4 the middle estimate is 7 percentage points above the measured one; the range from low to high includes it.
By their numbers in this assay, from the lowest: compounds 4, 1 and 3 (each within the scatter of the next); then compound 2.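

In this assay, the step of a number 18 percentage points lower from compound 2 to compound 4 (beyond the scatter) shows that on this double-bonded chain carbon, furan-2-yl does not keep the level seen with 4-chlorophenyl. With furan-2-yl in place, (bromomethyl)carbonyl on the nitrogen changes nothing that can be told apart, as the step of a number 1 percentage points lower from compound 1 to compound 4 (within the scatter) stays within the scatter. No measurement at hand explains either result.

The compounds shown leave open whether (bromomethyl)carbonyl on the nitrogen matters when 4-chlorophenyl is present. They also leave open how a plain phenyl or a thiophene ring would fare at this position.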